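A few compounds are considered here, and "the series" means these few. Any claim that something is new, unique, unknown or untested is made for them only; others in the source may bear on it.

Compound 1 (`O=C(O)COc1ccc(NCc2cccc(-c3ccccc3F)c2)cc1F`) and compound 2 (`Cc1ccccc1-c1cccc(CNc2ccc(OCC(=O)O)c(F)c2)c1`) share a core and differ only in one group on an aromatic ring. In a physicochemical assay for lipophilicity, read by HPLC, in phosphate buffer, measured as octanol-water partition, at pH 7.4, tested at 100 uM (on this read-out lower numbers stand for lower lipophilicity and higher numbers for higher lipophilicity), compound 1 gives 2.36, and compound 2 gives 2.41. Within the data shown here, compound 3 (`N#Cc1ccccc1-c1cccc(CNc2ccc(OCC(=O)O)c(F)c2)c1`) has no place on this scale, as its entry reads "not determined" (no result reported), so no step can be counted from it.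

Compound 4 (`Cc1ccc(-c2cccc(CNc3ccc(OCC(=O)O)c(F)c3)c2)c(Cl)c1`) differs from compound 3 by one exchange: 2-chloro-4-methylphenyl in place of 2-cyanophenyl on an aromatic carbon. The nitrile-bearing group thus gives way to one that carries both chloro and methyl, on an aromatic carbon meta to a large group.

Among the measured compounds shown here, only one measured step bears on this, and only loosely. It is methyl in place of fluoro on an aromatic carbon, a number 0.05 log units higher from compound 1 to compound 2 (within the scatter). For the measured compounds named here, that step shows a small exchange on this ring leaving this assay unmoved, but it is not the same change, and no measured compound carries the entering group. The reading for compound 4 must therefore be anchored on compound 1 and compound 2 rather than on compound 3. A modest rise over those two is expected, though it may not clear the scatter, and the data offer no direct support for it. For compound 4 the estimated value is 2.7, with an expected range from 2.3 to 3.1.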

Compound 4, distribution coefficient: 3.24
The estimate for compound 4 lay 0.54 log units below the measured number; measured number above the stated range.
By their numbers in this assay, from the lowest: compounds 1 and 2 (each within the scatter of the next); then compound 4.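

In this assay, the aromatic carbon meta to a large group proves able to carry a clear shift: the exchange of the 2-methylphenyl group for 2-chloro-4-methylphenyl gives a number 0.83 log units higher from compound 2 to compound 4 (beyond the scatter), and that of the 2-fluorophenyl group for the same entering group gives a number 0.88 log units higher from compound 1 to compound 4 (beyond the scatter). The one step seen before, a number 0.05 log units higher from compound 1 to compound 2 (within the scatter), had shown no such separation, so compound 4 now stands apart from compounds 1 and 2, which stay within the scatter of each other. Nothing in the data shows what lies behind this rise.

Whether the chloro, the methyl or the two together account for the rise stays open, as does where a 2-chlorophenyl or a 4-methylphenyl group alone would fall on this scale. Among these compounds, how a methoxy group or an amine on this ring would read in this assay also remains open, and the 2-cyanophenyl group of compound 3 still has no number, so no step from it can be read.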